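Swapping a methoxy for a fluoro on a weak cell-growth inhibitor

The source may report more compounds than this note shows. Statements on the series, on what has been measured and on what is new or still open speak of the compounds shown alone.

Measured compounds:
- compound 1, `Cc1ccc(C(=O)Nc2ccc(CNC(=O)OCc3cccnc3)cc2)c(N2CCCC2)c1`: 75200 nM
- compound 2, `COc1ccc(N2CCCC2)c(C(=O)Nc2ccc(CNC(=O)OCc3cccnc3)cc2)c1`: 47200 nM

Both compounds were tested in a functional assay on SGC-7901 cells (Homo sapiens) for inhibition, read by MTT assay, with a stated time of 72 h; a lower number here means a stronger inhibitor, a higher number a weaker inhibitor. In this assay compound 1 gives 75200 nM, and compound 2 gives 47200 nM. Compound 2 holds the lowest of the two numbers, but its nearest neighbour, compound 1, sits within the usual scatter of it, so the two cannot be told apart on these figures; both are weak inhibitors.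

Compound 3, `O=C(NCc1ccc(NC(=O)c2cc(F)ccc2N2CCCC2)cc1)OCc1cccnc1`, has not yet been measured in this assay. It differs from compound 2 in one place: fluoro in place of methoxy on an aromatic carbon.

Within the data shown here, no pair of measured compounds shows what such a change does here. The two measured compounds carry different small groups at the same place on that ring and give numbers within the scatter of each other, which gives no reason to expect a step beyond the scatter in either direction. The expected step from compound 2 to compound 3 in this assay is therefore a 1.2-fold higher number from compound 2 to compound 3 (0.07 log units; within the scatter). Compound 3 is expected to give about 55000 nM, most likely between 25000 nM and 120000 nM.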

Compound 3, half-maximal inhibitory concentration: 44800 nM
Estimate against measurement, compound 3: 1.2-fold (0.09 log units) above, within the range that was stated.
By their numbers in this assay, from the lowest: compounds 3, 2 and 1 (each within the scatter of the next).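

In this assay, replacing methoxy with fluoro on the aromatic carbon para to the pyrrolidin-1-yl group gives a 1.1-fold lower number from compound 2 to compound 3 (0.02 log units; within the scatter) and so leaves the two compounds indistinguishable on these figures. Among these compounds, this pair is the first direct reading of the swap: a group of two heavy atoms with one hydrogen-bond acceptor leaves, and a single fluorine with no hydrogen-bond acceptor counted enters, with no measurable consequence for the number. At this position, then, these two small groups can be exchanged without compound 3 moving beyond the scatter of compound 2, and both remain weak inhibitors. No evidence is available that bears on this result.

With only methoxy and fluoro compared directly at this place, the pair cannot show whether the position is insensitive to substitution in general or whether these two groups merely happen to give similar numbers. An amine, a carboxylic acid or a longer chain such as butoxy at the same carbon would test whether any group there can shift the number beyond the scatter.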